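A few compounds are considered here, and "the series" means these few. Any claim that something is new, unique, unknown or untested is made for them only; others in the source may bear on it.

The four compounds here share one core and differ only in the chain that hangs from one of its aromatic nitrogens. Compound 1 `COc1cc(Cc2nc3c(N)ncnc3n2CCCO)cc(OC)c1OC` and compound 2 `COc1cc(Cc2nc3c(N)ncnc3n2CCCCCO)cc(OC)c1OC` carry chains ending in a hydroxy group; in a functional assay on MCF7 cells (Homo sapiens) for cytotoxicity (on this read-out higher numbers stand for an effect only at larger amounts of compound and lower numbers for an effect already at smaller amounts), compound 1 gives 92700000 nM and compound 2 gives 84900000 nM. For the measured compounds named here, the only measured step between neighbours, a 1.1-fold lower number from compound 1 to compound 2 (0.04 log units; within the scatter), is small. Compound 3 `CCCCCn1c(Cc2cc(OC)c(OC)c(OC)c2)nc2c(N)nc(F)nc21` carries a plain pentyl chain and a fluorine on the core; in this assay compound 3 gives 286000000 nM, the highest number of the three, with compound 1 nearest and compound 2 furthest, and both of those gaps stand beyond the scatter.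

Compound 4 `CC#CCCn1c(Cc2cc(OC)c(OC)c(OC)c2)nc2c(N)nc(F)nc21` differs from compound 3 in one place: prop-1-yn-1-yl in place of propyl on a saturated chain carbon, two bonds along the chain from an aromatic nitrogen. Going by the values given here, no measured step tells what introducing a triple bond into this chain does. Among the compounds with values here, the one step that is known, a 1.1-fold lower number from compound 1 to compound 2 (0.04 log units; within the scatter), concerns the far end of a hydroxy-bearing chain and lies within the scatter, so it gives no reason to expect movement. The step from compound 3 to compound 4 in this assay is therefore expected to be about a 1.1-fold lower number from compound 3 to compound 4 (0.06 log units; within the scatter), a change not beyond the scatter. On that basis compound 4 is estimated at 250000000 nM, within a range from 70000000 nM to 900000000 nM.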

Compound 4, half-maximal effective concentration: 95500000 nM
Beside the measured number, compound 4's estimate is 2.6-fold (0.42 log units) above it; the range from low to high includes it.
By their numbers in this assay, from the lowest: compounds 2, 1 and 4 (each within the scatter of the next); then compound 3.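

In this assay, the change on a saturated chain carbon, two bonds along the chain from an aromatic nitrogen, gives a 3.0-fold lower number from compound 3 to compound 4 (0.48 log units; beyond the scatter) even though propyl and prop-1-yn-1-yl both have 3 heavy atoms (3 carbon) and differ in that prop-1-yn-1-yl holds a triple bond. For the compounds shown here, the earlier step, a 1.1-fold lower number from compound 1 to compound 2 (0.04 log units; within the scatter), lay within the scatter and concerned chains ending in a hydroxy group, so this is the first one-place change here to shift the number beyond the scatter, showing that on this fluorine-bearing core the read-out responds to the make-up of a chain and not only to its heavy-atom count. Nothing measured here says why the number moves.

The compounds shown leave open whether a double bond at this place, a triple bond further along the chain, or a longer chain would shift the number in the same direction. They also leave open whether the same change would have a similar effect on the core of compound 1, which has no fluorine, or on a chain ending in an amine.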